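Methyl to ethyl on the piperazine of compound 3

The compounds below may be only part of what the source reports. "The series", "measured", "known", "first", "only" and "open" are said of these compounds alone.

Of the compounds shown here, three sharing one core have been measured in an assay on HEK293 cells for inhibition of acid ceramidase (Homo sapiens), read by fluorescence, with stated times of 10 min and 3 h; a higher number here means a weaker inhibitor, a lower number a stronger inhibitor. Compound 1 `CC(C)N1CCC(c2ccc3c(c2)oc(=O)n3C(=O)NCCCCc2ccccc2)CC1` gives 94 nM. Compound 2 `CN1CCC(c2ccc3c(c2)oc(=O)n3C(=O)NCCCCc2ccccc2)CC1=O` gives 105 nM. Compound 3 `CN1CCN(c2ccc3c(c2)oc(=O)n3C(=O)NCCCCc2ccccc2)CC1` gives 116 nM. The three numbers sit close together: a 1.1-fold higher number from compound 1 to compound 2 (0.05 log units; within the scatter), a 1.2-fold higher number from compound 1 to compound 3 (0.09 log units; within the scatter) and a 1.1-fold higher number from compound 2 to compound 3 (0.04 log units; within the scatter) are all within the scatter, so no one of the three can be called stronger or weaker than the others, and compound 3 merely holds the highest of three numbers that are not distinguishable.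

Compound 4 `CCN1CCN(c2ccc3c(c2)oc(=O)n3C(=O)NCCCCc2ccccc2)CC1` differs from compound 3 by methyl in place of hydrogen on a saturated chain carbon bound to an amine nitrogen in a ring. For the measured compounds named here, none of the measured steps touches this carbon: each of them swapped one whole ring for another on the aromatic carbon, and those swaps, a 1.1-fold higher number from compound 1 to compound 2 (0.05 log units; within the scatter), a 1.2-fold higher number from compound 1 to compound 3 (0.09 log units; within the scatter) and a 1.1-fold higher number from compound 2 to compound 3 (0.04 log units; within the scatter), all stayed within the scatter. Going by the values given here, there is thus no measured step that bears directly on adding a methyl here, and the only guidance is that the region has so far tolerated larger changes without a shift beyond the scatter. Compound 4 is therefore expected to show no step beyond the scatter, no change at the digits printed from compound 3 to compound 4 (within the scatter). Compound 4 is estimated at 116 nM, within a range of 55 nM to 250 nM.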

Compound 4, half-maximal inhibitory concentration: 56 nM
The estimate for compound 4 lay 2.1-fold (0.32 log units) above the measured number; measured number inside the range.
By their numbers in this assay, from the lowest: compounds 4, 1, 2 and 3 (each within the scatter of the next, the first and the last beyond it).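

In this assay, the change from methyl to ethyl on the 4-methylpiperazin-1-yl group is the first change at this carbon and the first step among these compounds to pass the scatter, with a 2.1-fold lower number from compound 3 to compound 4 (0.32 log units; beyond the scatter) as a modest result, so this one added carbon counts for more here than the whole-ring swaps among the earlier compounds did. The gain in the number does not set compound 4 apart from the other two ring groups, since the swaps to 4-ethylpiperazin-1-yl give a 1.9-fold lower number from compound 2 to compound 4 (0.27 log units; within the scatter) and a 1.7-fold lower number from compound 1 to compound 4 (0.22 log units; within the scatter) and leave compound 4 level with compound 2 and compound 1. Nothing at hand explains why the added methyl moves the number.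

As far as these compounds go, it remains open whether a longer chain such as propyl, or a chain carrying a hydroxyl group such as 2-hydroxyethyl, in place of the ethyl of the 4-ethylpiperazin-1-yl group would lower the number further or give it back. From the compounds shown here alone, it is equally open whether ethyl in place of the methyl of the 1-methyl-2-oxopiperidin-4-yl group would give a step like the one seen on the piperazine.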